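Carboxy Gives Way to Methyl in Compound 4

The source may report more compounds than this note shows. Statements on the series, on what has been measured and on what is new or still open speak of the compounds shown alone.

Compound 1 `CC1(C)Oc2ccc(C#N)cc2[C@@H](/N=C(\NC#N)Nc2ccc(Cl)cc2)[C@@H]1O`: 1800 nM
Compound 2 `CC1(C)Oc2ccc(C#N)cc2[C@@H](/N=C(\NC#N)Nc2ccc(C(F)(F)F)cc2)[C@@H]1O`: 8100 nM
Compound 3 `CC1(C)Oc2ccc(C#N)cc2[C@@H](/N=C(\NC#N)Nc2ccc(C(=O)O)cc2)[C@@H]1O`: > 100000 nM

These values come from a functional assay (aorta) with Rattus norvegicus as the target; a higher number here means a weaker inhibitor, a lower number a stronger inhibitor. For compound 3 the reading > 100000 nM is only a limit, not a number. Compound 4 `Cc1ccc(N/C(=N/[C@@H]2c3cc(C#N)ccc3OC(C)(C)[C@H]2O)NC#N)cc1` has methyl in place of carboxy on an aromatic carbon, para to a large group (methyl in place of carboxy on an aromatic carbon). Among the compounds with values here, two measured steps bear most directly on this change, both large: an at least 55-fold higher number from compound 1 to compound 3 (1.74 log units; beyond the scatter) and an at least 12-fold higher number from compound 2 to compound 3 (1.09 log units; beyond the scatter). The chloro and trifluoromethyl compounds themselves differ only modestly, with a 4.5-fold higher number from compound 1 to compound 2 (0.65 log units; beyond the scatter). Removing carboxy is therefore expected to give a large step towards a lower number in this assay. The expected change is an at least 25-fold lower number from compound 3 to compound 4 (1.39 log units; beyond the scatter). Compound 4 is estimated at 4000 nM, with an expected range of 1200 nM to 15000 nM.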

Compound 4, half-maximal inhibitory concentration: 2700 nM
Estimate against measurement, compound 4: 1.5-fold (0.17 log units) above; low and high end bracket the measured number.
By their numbers in this assay, from the lowest: compounds 1 and 4 (each within the scatter of the next); then compound 2. At a limit, above all of these: compound 3.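

In this assay, the step of an at least 37-fold lower number from compound 3 to compound 4 (1.56 log units; beyond the scatter) gives a bound and not a size: the limit of > 100000 nM in this assay, at which 1 of the 4 values shown sits.
Methyl and chloro cannot be told apart, with a 1.5-fold higher number from compound 1 to compound 4 (0.18 log units; within the scatter), while trifluoromethyl stays separate from methyl, with a 3.0-fold lower number from compound 2 to compound 4 (0.48 log units; beyond the scatter). Among the four groups at this place, only carboxy takes the reading to a limit, and the other three are separated by modest steps at most.

The compounds shown leave open whether an amine, a methyl ester or a carboxamide here would read like methyl and chloro or like carboxy.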